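This account rests on a few compounds, and the source may have more. Where it says the series, first, only, none or still open, it means among the compounds named here.

In an assay on NIH3T3 cells with Urotensin-2 receptor (Homo sapiens) as the target (a higher number here means a larger maximal response, a lower number a smaller maximal response), the measured compounds stand as follows:

compound 1 `COc1ccc(C(=O)OC(CCN(C)C)c2ccc(Cl)cc2)cc1`: 84%
compound 2 `Cc1ccc(C(=O)OC(CCN(C)C)c2ccc(Cl)cc2)cc1`: 56%
compound 3 `Cc1cccc(C(=O)NC(CCN(C)C)c2ccc(Cl)cc2)c1C`: 159%

Compound 3 holds the highest value of the three, beyond the scatter from both compound 1 and compound 2. The change methoxy in place of methyl on an aromatic carbon produced a number 28 percentage points higher from compound 2 to compound 1 (beyond the scatter) in this assay. The difference between the core of compound 2 and the core of compound 3 is not broken down here.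

Compound 4 `COc1cccc(C(=O)NC(CCN(C)C)c2ccc(Cl)cc2)c1C` differs from compound 3 by methoxy in place of methyl on an aromatic carbon. This is the same kind of change as from compound 2 to compound 1, not the same: there the place was para to a large group, here it is ortho to a methyl group and meta to a large group.

For compound 4 a step of a number 16 percentage points higher from compound 3 to compound 4 (beyond the scatter) in this assay is expected, resting on the upward step a number 28 percentage points higher from compound 2 to compound 1 (beyond the scatter); because compound 3 already gives 159%, the expected range is kept wide. Compound 4 is estimated at 175%, between 125% and 225%.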

Compound 4, largest response reached (reported as efficacy), in percent of the reference or control that the assay uses: 179%
Compound 4: middle estimate off by 4 percentage points, on the low side; the range from low to high includes it.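

In this assay, methoxy in place of methyl on an aromatic carbon goes with a number 20 percentage points higher from compound 3 to compound 4 (beyond the scatter). For the compounds shown here, the change points the same way on both cores, and the size of the step carries over: the same change on two cores in this assay, a number 28 percentage points higher (beyond the scatter) from compound 2 to compound 1 and a number 20 percentage points higher (beyond the scatter) from compound 3 to compound 4, 8 percentage points apart, within the scatter of two such steps This rests on only two pairs, and the change sits at a different place on the ring in each, so core and place are not separated and the reason for the rise remains unknown.

Still open, as far as these compounds go, is whether ethoxy, hydroxyl or fluorine at this aromatic carbon would give a similar step. Also open, from the compounds shown here alone, is whether the step persists when piperidine replaces the dimethylamino group.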